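Inverting Two Ring Stereocentres at a Long Half-Life

The compounds below may be only part of what the source reports. "The series", "measured", "known", "first", "only" and "open" are said of these compounds alone.

In an ADME assay on microsomes from liver (Mus musculus) for metabolic stability (a higher number here means that the compound lasts longer, a lower number that the compound disappears faster), compound 1 `CCO[C@@H]1O[C@H](CNC(=O)c2ccc(S(N)(=O)=O)cc2)[C@@H](O)[C@H](O)[C@H]1O` gives 59.5 h and compound 2 `CCO[C@@H]1O[C@H](CNC(=O)c2ccc(S(N)(=O)=O)cc2)[C@H](O)[C@H](O)[C@H]1O` gives 61.1 h so compound 2 stands level with compound 1 within the scatter. Compound 3 `CCO[C@@H]1O[C@H](CNC(=O)c2ccc(S(N)(=O)=O)cc2)[C@@H](O)[C@H](O)[C@@H]1O` departs from compound 2 in configuration alone: the two compounds have the same atoms and bonds and differ only in configuration as drawn: 2 of 5 stereo elements differ; a stereocentre at a saturated ring carbon is drawn R in compound 2 and S in compound 3; a stereocentre at a saturated ring carbon is drawn R in compound 2 and S in compound 3 and nothing else changes. Going by the values given here, one measured step bears on this, a 1.0-fold higher number from compound 1 to compound 2 (0.01 log units; within the scatter) for a pair defined by the fact that compounds 1 and 2 differ only in the configuration as drawn and involving one stereocentre only. No step beyond the scatter is therefore expected in this assay although two stereocentres change here. The estimated step is a 1.1-fold lower number from compound 2 to compound 3 (0.05 log units; within the scatter) and stays small. For compound 3 the estimate is 55 h with an expected range from 28 h to 100 h in this measurement.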

Compound 3, half-life: 61.6 h
The estimate for compound 3 lay 1.1-fold (0.05 log units) below the measured number, within the range that was stated.
By their numbers in this assay, from the lowest: compounds 1, 2 and 3 (each within the scatter of the next).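

In this assay, inverting two ring stereocentres at once gives a 1.0-fold higher number from compound 2 to compound 3 (0.00 log units; within the scatter), so changing both together leaves the half-life as level as the single inversion did. A different single ring stereocentre, inverted alone, gives a 1.0-fold higher number from compound 1 to compound 3 (0.02 log units; within the scatter), which adds a second position where configuration alone shifts nothing beyond the scatter. All three compounds therefore stand level, whichever of these configurations is drawn.

From the compounds shown here alone, what remains open is whether the half-life would hold if an amine or a carboxylic acid took the place of a ring hydroxyl group on the shared core.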